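The source may hold more compounds than are shown below. What is called first, only, known or untested is meant among the compounds shown, and "the series" means these compounds.

Working notes on the series.

Compound 1 `CNC(=S)N1N=C(c2ccc(C)cc2)CC1c1ccc[nH]1` gives 13.2% in a functional assay on the whole organism (strain Swiss Albino) for inhibition, with Mus musculus as the target, read by paw edema, with a stated time of 90 min, at a dose of 100 mg/kg by the oral route; a higher number here means more inhibition at the dose given (going by the name of the read-out), a lower number less inhibition. Compound 2 `CCNC(=S)N1N=C(c2ccc(C)cc2)CC1c1ccc[nH]1` carries methyl in place of hydrogen on a saturated chain carbon bound to an amide-type nitrogen and gives 4.9% in this assay; the step is a number 8.3 percentage points lower from compound 1 to compound 2 (within the scatter). Compound 3 `CCNC(=S)N1N=C(c2ccc(OC)cc2)CC1c1ccc[nH]1` gives 23.2% in this assay; the step of a number 18.3 percentage points higher from compound 2 to compound 3 (beyond the scatter) is the only one among these three that falls beyond the scatter. The difference between the cores of compound 1 and compound 3 is not broken down here; their two values lie within the scatter of each other.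

Compound 4 `CCCNC(=S)N1N=C(c2ccc(OC)cc2)CC1c1ccc[nH]1` awaits measurement in this assay. It differs from compound 3 by methyl in place of hydrogen on a saturated chain carbon, two bonds along the chain from an amide-type nitrogen. This is the same kind of change as from compound 1 to compound 2, though not the same: there the entering methyl sat on a saturated chain carbon bound to an amide-type nitrogen, here it sits on a saturated chain carbon two bonds along the chain from an amide-type nitrogen. Among the measured compounds shown here, the single earlier instance, a number 8.3 percentage points lower from compound 1 to compound 2 (within the scatter), gives the only guide, and it stayed within the scatter. A step of comparable, small size is therefore expected for compound 4, namely a number 4.2 percentage points lower from compound 3 to compound 4 (within the scatter), because the earlier step of a number 8.3 percentage points lower from compound 1 to compound 2 (within the scatter) was itself within the scatter. Compound 4 is expected to give 19%, between 7% and 31%.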

Compound 4, a percentage reported as inhibition, in the whole organism at one dose (the size of the read-out at that dose, not a potency): 20.3%
Compound 4: the middle estimate sits 1.3 percentage points below what was measured; the range from low to high includes it.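

In this assay, methyl in place of hydrogen on a saturated chain carbon, two bonds along the chain from an amide-type nitrogen, gives a number 2.9 percentage points lower from compound 3 to compound 4 (within the scatter), and the two instances of this kind of change agree: the same change on two cores in this assay, a number 8.3 percentage points lower (within the scatter) from compound 1 to compound 2 and a number 2.9 percentage points lower (within the scatter) from compound 3 to compound 4, 5.4 percentage points apart, within the scatter of two such steps

On these two cores, then, adding a methyl to the chain does not move the number beyond the scatter, and in that limited sense the result carries from one core to the other. This does not show that the change has no effect or that its size is the same on both cores, since each step rests on a single pair, both lie within the scatter, and the entering methyl sits at a different place on the chain in each.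

The compounds shown leave open how a longer chain than propylamino, or an amine or a carboxylic acid at the end of that chain, would read in this assay. They also leave open whether the chain change behaves the same way with a chlorine or a nitro group in place of the methoxy.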